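Methyl for propargyl on the sulfanyl arm of compound 3

The source may hold more compounds than are shown below. What is called first, only, known or untested is meant among the compounds shown, and "the series" means these compounds.

Compound 2 `C#CC[Se]c1c(SCC#CCO)cnc2ccccc12` and compound 1 `C[Se]c1c(SCC#CCO)cnc2ccccc12` share one core and differ by hydrogen in place of ethynyl on a saturated chain carbon bound to a selenium atom. Among the measured compounds shown here, in a functional assay on CCRF-CEM cells (Homo sapiens) for cytotoxicity, read by sulforhodamine B assay, with a stated time of 72 h (a lower number here means a stronger inhibitor, a higher number a weaker inhibitor), compound 2 gives 1.9 ug/mL, and compound 1 gives 2.1 ug/mL; the step of a 1.1-fold higher number from compound 2 to compound 1 (0.04 log units; within the scatter) is the only measured example of this exchange in the set. Compound 3 `C#CCSc1cnc2ccccc2c1[Se]CC#CCO` is built from the same atoms as compound 2 joined differently; the difference between the two cores is not broken down here. In this assay compound 3 gives 3.2 ug/mL, a number that sits within the scatter of both compound 1 and compound 2, so no order among the three can be read.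

Compound 4 `CSc1cnc2ccccc2c1[Se]CC#CCO` has not been measured. It differs from compound 3 by hydrogen in place of ethynyl on a saturated chain carbon bound to a sulfur. This is the same kind of change as that from compound 2 to compound 1, but not the same: there the place is on a saturated chain carbon bound to a selenium atom, here it is on a saturated chain carbon bound to a sulfur. The expectation rests on compound 2 and compound 1, because a 1.1-fold higher number from compound 2 to compound 1 (0.04 log units; within the scatter) shows the exchange moving the number very little at the other arm. For compound 4 a similarly small step is expected, a 1.1-fold higher number from compound 3 to compound 4 (0.04 log units; within the scatter). Since the place differs and a single prior example exists, the range is kept wide. For compound 4 in this assay the estimate is 3.5 ug/mL, expected to fall between 1.7 ug/mL and 7.5 ug/mL.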

Compound 4, concentration for 50% inhibition: 0.5 ug/mL
Compound 4: middle estimate off by 7.0-fold (0.85 log units), on the high side; the whole stated range lies above it.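

In this assay, among the compounds shown here, methyl for propargyl on the sulfanyl arm of the core of compound 3 gives a 6.4-fold lower number from compound 3 to compound 4 (0.81 log units; beyond the scatter) and is the only step so far that lies beyond the scatter. Set against the earlier step, the exchange does not carry over in size from one core to the other: the same change on two cores in this assay, a 1.1-fold higher number (0.04 log units; within the scatter) from compound 2 to compound 1 and a 6.4-fold lower number (0.81 log units; beyond the scatter) from compound 3 to compound 4, 7.1-fold (0.85 log units) apart, beyond the scatter of two such steps

The flat result from the selenium-bound arm therefore cannot be used to predict the same exchange on the sulfur-bound arm, and the two cases have to be read separately in this series. What this does not show is a rule or a cause: each core offers a single pair, so the gap rests on two steps in one cell assay, and these pairs alone cannot say whether it comes from the chalcogen atom bearing the exchanged group or from something else that differs in the two cores.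

From the compounds shown here alone, it remains open whether ethyl or a longer chain on the sulfur keeps the number near that of compound 4 or moves it back toward that of compound 3. Also open, going by these compounds, is how compound 4 responds when an amine or a carboxylic acid takes the place of the hydroxyl at the end of the selenium-bound chain.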